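Amide-nitrogen aryl swap: pyridinyl to chlorophenyl

This account rests on a few compounds, and the source may have more. Where it says the series, first, only, none or still open, it means among the compounds named here.

In an ADME assay on MDCK cells (Canis lupus familiaris) for cytotoxicity (on this read-out lower numbers stand for higher toxicity in this test and higher numbers for lower toxicity in this test), compound 1 `CN(C(=O)C1(c2ccccc2)CCCC1)c1ccccc1` gives 52000 nM. Compound 2 `CN(C(=O)C1(c2ccccc2)CCCC1)c1cccnc1` reaches only a limit of this assay, > 100000 nM, so its position is known merely as a floor. Among the measured compounds shown here, the sole measured comparison is an at least 1.9-fold higher number from compound 1 to compound 2 (0.28 log units; that floor lies within the scatter), and it rests on that limit (the limit of > 100000 nM in this assay, at which 1 of the 2 values shown sits). Compound 3 `CN(C(=O)C1(c2ccccc2)CCCC1)c1ccc(Cl)cc1` carries the change (4-chlorophenyl in place of pyridin-3-yl on an amide-type nitrogen), which largely walks back toward the aryl of compound 1. The expected step of an at least 2.5-fold lower number from compound 2 to compound 3 (0.39 log units; beyond the scatter) is therefore a lower number, roughly undoing the earlier move. Compound 3 is estimated at 40000 nM, within 15000 nM to 100000 nM.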

Compound 3, half-maximal cytotoxic concentration: 20000 nM
For compound 3 the middle estimate is 2.0-fold (0.30 log units) above the measured one; the range from low to high includes it.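

In this assay, the swap on the amide-type nitrogen gives an at least 5.0-fold lower number from compound 2 to compound 3 (0.69 log units; beyond the scatter), and chloro in place of hydrogen on an aromatic carbon gives a 2.6-fold lower number from compound 1 to compound 3 (0.41 log units; beyond the scatter). Both steps lie beyond the scatter, unlike the earlier floor, so the chloro alone shifts this read-out toward higher toxicity. The first step is only a floor, as compound 2 stands at a limit of the assay: the limit of > 100000 nM in this assay, at which 1 of the 3 values shown sits.

Open, as far as these compounds go, is whether a methoxy or an amine in place of the chloro moves the read-out the same way. Also open, from the compounds shown here alone, is how far compound 2 lies past its limit.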